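This account rests on a few compounds, and the source may have more. Where it says the series, first, only, none or still open, it means among the compounds named here.

Measured compounds in a functional assay on DLD-1 cells (Homo sapiens) for antiproliferative activity, read by CellTiter-Glo, with a stated time of 72 h; a lower number here means a stronger inhibitor, a higher number a weaker inhibitor:
- compound 1 `COc1ccccc1-c1cccc(S(=O)(=O)N2CCC(N3CCC(C)CC3)CC2)c1` gives 21 nM
- compound 2 `COc1cc(C)ccc1S(=O)(=O)N1CCC(N2CCC(C)CC2)CC1` gives > 5000 nM
- compound 3 `Cc1cc(C)c(S(=O)(=O)N2CCC(N3CCC(CCO)CC3)CC2)c(C)c1` gives 19 nM

The value of compound 2 is a limit of the assay, not a number. Compound 2 sits at the limit of > 5000 nM in this assay, at which 1 of the 3 values shown sits. Of the two numbers, compound 3 gives the lower one, yet compound 1 lies within the usual scatter of it, so the two cannot be told apart. Compound 4 `Cc1cc(C)c(S(=O)(=O)N2CCC(N3CCC(C(C)C)CC3)CC2)c(C)c1` differs from compound 3 by isopropyl in place of 2-hydroxyethyl on a saturated ring carbon. Among the compounds with values here, no measured step covers this change. Since compound 1 with its methyl on that ring and compound 3 with its 2-hydroxyethyl are alike in this assay, the step from compound 3 to compound 4 is expected to stay within the scatter, a 1.3-fold higher number from compound 3 to compound 4 (0.12 log units; within the scatter). Compound 4 is therefore estimated at 25 nM, between 8 nM and 80 nM.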

Compound 4, half-maximal inhibitory concentration: 0.3 nM
Compound 4: the middle estimate sits 83-fold (1.92 log units) above what was measured, outside the stated range (below it).
By their numbers in this assay, from the lowest: compound 4; then compounds 3 and 1 (each within the scatter of the next). At a limit, above all of these: compound 2.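

In this assay, isopropyl in place of 2-hydroxyethyl on this saturated ring carbon gives a 63-fold lower number from compound 3 to compound 4 (1.80 log units; beyond the scatter), and this is the first pair shown that differs only here. The position therefore responds strongly to its group, even though both groups count 3 heavy atoms and neither has a ring. Nothing measured here accounts for the size of this step. The compounds shown leave open whether the branching or the missing hydroxyl matters, which an n-propyl or a 2-methoxyethyl group at this place would help to separate.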